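Lengthening the Ester Side Chain of Compound 3

The compounds below may be only part of what the source reports. "The series", "measured", "known", "first", "only" and "open" are said of these compounds alone.

Compound 3 `O=C(C[C@H](NC(=O)c1cc2ccccc2cn1)C(=O)OCc1ccccc1)OCc1ccccc1` gives 411 nM in a functional assay on HeLa cells (Homo sapiens) for antiproliferative activity, read by MTT assay, with a stated time of 48 h; a lower number here means a stronger inhibitor, a higher number a weaker inhibitor. Within the data shown here, of the three compounds measured so far it carries the highest number: compound 1 `CC(C)[C@H](NC(=O)c1cc2ccccc2cn1)C(=O)OCc1ccccc1` gives 118 nM and compound 2 `O=C(N[C@@H](CO)C(=O)OCc1ccccc1)c1cc2ccccc2cn1` gives 135 nM, with the steps of a 3.5-fold higher number from compound 1 to compound 3 (0.54 log units; beyond the scatter) and a 3.0-fold higher number from compound 2 to compound 3 (0.48 log units; beyond the scatter) both beyond the scatter, while a 1.1-fold higher number from compound 1 to compound 2 (0.06 log units; within the scatter). Compound 4 `O=C(CC[C@H](NC(=O)c1cc2ccccc2cn1)C(=O)OCc1ccccc1)OCc1ccccc1` differs from compound 3 by (benzyloxycarbonyl)methyl in place of benzyloxycarbonyl on a saturated chain carbon, two bonds along the chain from an amide-type nitrogen and a carbonyl carbon. Among the measured compounds shown here, no measured pair repeats this change. For the measured compounds named here, the only steps that touch the same region of the molecule are the two that brought in the benzyloxycarbonyl-bearing side chain, and each of them raised the number modestly. Compound 4 keeps that side chain and moves its terminus one bond further out. On that basis the expected step of a 1.2-fold higher number from compound 3 to compound 4 (0.07 log units; within the scatter) is small, within or close to the scatter, if anything towards a slightly higher number. For compound 4 the estimate in this assay is 480 nM, with a range from 200 nM to 1200 nM.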

Compound 4, half-maximal inhibitory concentration: 214 nM
Estimate against measurement, compound 4: 2.2-fold (0.35 log units) above, and the stated range covers the measured number.
By their numbers in this assay, from the lowest: compounds 1, 2, 4 and 3 (each within the scatter of the next, the first and the last beyond it).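

In this assay, going from the benzyloxycarbonyl side chain of compound 3 to the one carbon longer chain gives a 1.9-fold lower number from compound 3 to compound 4 (0.28 log units; within the scatter), so at this place on a saturated chain carbon the added carbon does not separate the two compounds. The other two steps, a 1.6-fold higher number from compound 2 to compound 4 (0.20 log units; within the scatter) and a 1.8-fold higher number from compound 1 to compound 4 (0.26 log units; within the scatter), also lie within the scatter, so 2-(benzyloxycarbonyl)ethyl, unlike the shorter ester chain of compound 3, cannot be told apart from hydroxymethyl or isopropyl here. Nothing given here accounts for this result.

Two ester chain lengths that lie within the scatter of each other cannot establish a trend with length. Going by these compounds, how a free carboxylic acid or an amine at the end of this chain, or a chain longer than 2-(benzyloxycarbonyl)ethyl, would read in this assay remains open.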